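Amide aryl replacement in a lipophilicity series

The source may hold more compounds than are shown below. What is called first, only, known or untested is meant among the compounds shown, and "the series" means these compounds.

Compound 1 `COc1ccc2c(OCC(=O)Nc3cc(C)cc(C)c3)cc(C)nc2c1`: in a physicochemical assay for lipophilicity, read by HPLC, in phosphate buffer, measured as chromatographic lipophilicity, at pH 7.4 (on this read-out lower numbers stand for lower lipophilicity and higher numbers for higher lipophilicity), compound 1 gives 5.59.
Compound 2 `CCC(Oc1cc(C)nc2ccc(OC)cc12)C(=O)Nc1cc(C)cc(C)c1`: in this assay compound 2 gives 6.28.
Compound 3 `COc1ccc2nc(C)cc(OCC(=O)Nc3cccc(C)c3)c2c1`: in this assay compound 3 gives 4.83.

Compound 3 stands lowest of the three numbers. Compound 1 is the nearest, yet its value lies higher by a margin beyond the scatter; compound 2 is the furthest, higher still and also beyond the scatter. The three share one core and differ only in the amide portion.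

Compound 4 `COc1ccc2nc(C)cc(OCC(=O)Nc3noc(C)c3C)c2c1` has not been measured. It differs from compound 3 in one place: 4,5-dimethyl-1,2-oxazol-3-yl in place of 3-methylphenyl on an amide-type nitrogen. Within the data shown here, no measured pair shows the same change, so the expectation rests on the structural change alone. For compound 4 a step downward, well beyond the scatter, is expected, a number 1.23 log units lower from compound 3 to compound 4 (beyond the scatter). The estimated value for compound 4 in this assay is 3.6, with a range from 3 to 4.2. The measurement will show whether this expected drop holds.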

Compound 4, distribution coefficient: 3.3
Estimate against measurement, compound 4: 0.30 log units above; measured number inside the range.
By their numbers in this assay, from the lowest: compound 4; then compound 3; then compound 1; then compound 2.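

In this assay, the amide-type nitrogen now has its first single-place comparison: 4,5-dimethyl-1,2-oxazol-3-yl in place of 3-methylphenyl gives a number 1.53 log units lower from compound 3 to compound 4 (beyond the scatter), a large step. The two groups have the same heavy-atom count, so this step accompanies a change in ring make-up, from a six-membered aromatic ring of carbon only to a five-membered aromatic ring with 2 hetero atoms, and not a change in that count. Nothing measured here ties the step to a particular property of either group.

From the compounds shown here alone, it remains open how much of the step belongs to the ring itself and how much to its two methyl groups, a comparison that an unsubstituted 1,2-oxazol-3-yl or a pyridin-3-yl on the same nitrogen would inform. Going by these compounds, whether the same replacement gives a similar step on the amides of compound 1 or compound 2 also stays open.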